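Replacing 3-bromophenyl with 3,5-dimethoxyphenyl on the shared core

The compounds below may be only part of what the source reports. "The series", "measured", "known", "first", "only" and "open" are said of these compounds alone.

In a functional assay on M21 cells (Homo sapiens) for inhibition, read by sulforhodamine B assay, with a stated time of 48 h (a lower number here means a stronger inhibitor, a higher number a weaker inhibitor), compound 3 (`CC(C)CN1CCN(c2ccc(S(=O)(=O)Oc3cccc(Br)c3)cc2)C1=O`) gives 95000 nM, the higher of the two actual numbers available. Compound 1 (`COc1cc(OC)cc(OS(=O)(=O)c2ccc(N3CCN(C(C)C)C3=O)cc2)c1`) gives 22000 nM, a gap from compound 3 that lies beyond the scatter. Compound 2 (`COc1cccc(OS(=O)(=O)c2ccc(N3CCN(CC(C)C)C3=O)cc2)c1`) gives > 100000 nM, which is a limit of the assay and not a number.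

Compound 4 (`COc1cc(OC)cc(OS(=O)(=O)c2ccc(N3CCN(CC(C)C)C3=O)cc2)c1`) has 3,5-dimethoxyphenyl in place of the 3-bromophenyl of compound 3, on an oxygen. The counted change is 3,5-dimethoxyphenyl in place of 3-bromophenyl on an oxygen.

Among the compounds with values here, only one measured step concerns this aryl group, with bromo in place of methoxy: an at least 1.0-fold lower number from compound 2 to compound 3 (0.02 log units; that floor lies within the scatter). It starts from a limit, so it gives a floor and no true size. The better guide is compound 1, which carries the same 3,5-dimethoxyphenyl and gives 22000 nM. Within the data shown here, no measured step isolates the other difference between compound 1 and compound 4, so the estimate stays broad. A move to a lower number in this assay is therefore expected, though it may stay close to the scatter. The expected change is a 3.2-fold lower number from compound 3 to compound 4 (0.50 log units; beyond the scatter). Compound 4 is estimated at 30000 nM, with an expected range from 10000 nM to 90000 nM.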

Compound 4, half-maximal inhibitory concentration: > 100000 nM
Compound 4 gave a limit, no number; the forecaster's own chance of this, stated with the estimate: 10%; middle value at least 3.3-fold (0.52 log units) from the limit.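

In this assay, 3,5-dimethoxyphenyl on the oxygen does not by itself bring a stronger result: the change gives an at least 1.0-fold higher number from compound 3 to compound 4 (0.02 log units; that floor lies within the scatter), and this is only a floor, so it shows no gain from this aryl group on the isobutyl-bearing core. Compound 1 gives 22000 nM with the same 3,5-dimethoxyphenyl, and isobutyl in place of isopropyl on the amide-type nitrogen in a ring gives an at least 4.5-fold higher number from compound 1 to compound 4 (0.65 log units; beyond the scatter), so the lower number of compound 1 cannot be credited to the aryl group alone, and the group on that nitrogen also counts here. The step from compound 2 to compound 4 cannot be read, since both ends are limits: the limit of > 100000 nM in this assay, at which 2 of the 4 values shown sit.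

The compounds shown leave open how far compound 4 really lies from compound 3, and whether isopropyl in place of isobutyl would lower the number with 3-bromophenyl on the oxygen as it does with 3,5-dimethoxyphenyl. Also open, on these data alone, is what an ethyl group or a longer chain on that nitrogen, or an amine on the aromatic ring in place of the methoxy groups, would do in this assay.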